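Hydrogen for phenyl on the piperidine-bearing amide series

The source may hold more compounds than are shown below. What is called first, only, known or untested is meant among the compounds shown, and "the series" means these compounds.

The study concerns four compounds that share one core, differing in the chain and the ring attached to the second amide. Compound 1 `CS(=O)(=O)c1ccc(C(=O)NCCC(=O)N2CCCCC2)cc1[N+](=O)[O-]` was tested in an assay on isolated protein for inhibition of vitamin D3 receptor (Homo sapiens), read by fluorescence polarization (on this read-out lower numbers stand for stronger inhibition and higher numbers for weaker inhibition), and returned only a limit, > 60000 nM. Compound 2 `CS(=O)(=O)c1ccc(C(=O)NCCCC(=O)N2Cc3ccccc3C2)cc1[N+](=O)[O-]` likewise gave only a limit in this assay, namely > 60000 nM. Compound 3 `CS(=O)(=O)c1ccc(C(=O)NCCCC(=O)N2CCC(c3ccccc3)CC2)cc1[N+](=O)[O-]` stands at the same limit in this assay, with > 60000 nM. All three values sit at the assay's upper bound, as the limit of > 60000 nM in this assay, at which 3 of the 3 values shown sit, records, so no number separates them and nothing is known about where any of them truly lies.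

Compound 4 `CS(=O)(=O)c1ccc(C(=O)NCCCC(=O)N2CCCCC2)cc1[N+](=O)[O-]` has not yet been measured in this assay. It differs from compound 3 by hydrogen in place of phenyl on a saturated ring carbon. Since compound 3 gave only a limit, the step cannot be measured against a number, and nothing among the three compounds shows any effect of such a change. The writer therefore expects no step beyond the scatter, with compound 4 estimated to remain at the limit, the expected step from compound 3 being a step that the limit leaves unreadable from compound 3 to compound 4. The expected value for compound 4 is 70000 nM, within a range from 30000 nM to 200000 nM.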

Compound 4, half-maximal inhibitory concentration: > 60000 nM
Compound 4 was reported as a limit (the forecaster's own chance of this, stated with the estimate: 90%); the middle value does not contradict the limit.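

In this assay compound 4 gave > 60000 nM as a limit. For the compounds shown here, no step from compound 1, compound 2 or compound 3 to compound 4 can be read, because all four compounds share the same bound: the limit of > 60000 nM in this assay, at which 4 of the 4 values shown sit. The compounds shown leave open where any of the four truly lies, and whether changing the chain or ring alters inhibition at all.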